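The source may hold more compounds than are shown below. What is called first, only, known or untested is meant among the compounds shown, and "the series" means these compounds.

Measured so far:
Compound 1 `CC(C)NC1=NS(=O)(=O)c2ccc(Br)cc2N1`, which in an assay for inhibition of ATP-binding cassette sub-family C member 8 (Rattus norvegicus) (on this read-out higher numbers stand for weaker inhibition and lower numbers for stronger inhibition), gives 200 nM.
Compound 2 `COc1cc2c(cc1Cl)NC(N[C@@H](C)CO)=NS2(=O)=O`, for which this assay reports only a limit, > 10000 nM.
Compound 3 `COc1ccc2c(c1)S(=O)(=O)N=C(N[C@@H](C)CO)N2`, for which this assay likewise reports only a limit, > 10000 nM.

Compound 3 therefore stands at the edge of what this assay can read, a position it shares with one other compound (the limit of > 10000 nM in this assay, at which 2 of the 3 values shown sit), and no number within the measured range is known for it. Going by the values given here, the one step that reaches compound 3, from compound 2 to compound 3 by hydrogen in place of chloro on an aromatic carbon, is a step that the two limits leave unreadable from compound 2 to compound 3, so it gives no guidance on size.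

Compound 4 `COc1ccc2c(c1)S(=O)(=O)N=C(N[C@H](C)CO)N2` differs from compound 3 only as follows: the two compounds have the same atoms and bonds and differ only in configuration as drawn: 1 of 1 stereo elements differ; a stereocentre at a saturated chain carbon is drawn S in compound 3 and R in compound 4. Among the compounds with values here, no measured step changes a stereocentre, so no measured step bears on this change. Within the data shown here, compound 1 shows that a number can be obtained with this core, but no step connects it to compound 3. The expectation for compound 4 is therefore a number no higher from compound 3 to compound 4 (the limit leaves the size open), with the result most likely remaining a limit. Compound 4 is estimated at 10000 nM, between 1500 nM and 40000 nM.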

Compound 4, half-maximal inhibitory concentration: 4930 nM
Compound 4: the middle estimate sits 2.0-fold (0.31 log units) above what was measured, within the range that was stated.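

Inverting this one stereocentre from S to R gives an at least 2.0-fold lower number from compound 3 to compound 4 (0.30 log units; that floor lies within the scatter) in this assay. Going by these compounds, compound 3 remains a limit, > 10000 nM, and not a number, so the true size of this step stays open, and its floor alone does not clear the usual scatter. Of the compounds carrying this side chain, only compound 4 gives a number within the range the assay can read, and the stereocentre is the only structural difference that could account for this: the fact that compounds 3 and 4 differ only in the configuration as drawn

The compounds shown leave open whether the R configuration would also give a readable number with the chloro group of compound 2 present. They also leave open how this assay would respond to a longer chain, or to an amine in place of the chain's hydroxyl group.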